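Pyrrolidin-3-yl in place of ethyl: clearance notes

A few compounds are considered here, and "the series" means these few. Any claim that something is new, unique, unknown or untested is made for them only; others in the source may bear on it.

Compound 1 `CCn1nc(CC(=O)Nc2ccc(OC(F)(F)F)c(Cl)c2)c2ccccc2c1=O` is the starting point for this step. In an ADME assay on microsomes from liver (Mus musculus) for metabolic stability (on this read-out lower numbers stand for slow clearance and higher numbers for fast clearance), compound 1 gives 81.7 mL/min/kg and compound 2 `CC(C(=O)O)c1nn(Cc2cn3cc(OCC4CC4)c(Cl)cc3n2)c2ccccc2c1=O` gives 80 mL/min/kg on the same scale. These two values lie within the scatter of each other, so the numbers do not separate compound 1 from compound 2.

Among the compounds with values here, compound 3 `O=C(Cc1nn(C2CCNC2)c(=O)c2ccccc12)Nc1ccc(OC(F)(F)F)c(Cl)c1` keeps the rest of compound 1 and carries pyrrolidin-3-yl in place of ethyl on an aromatic nitrogen as its only change. Within the data shown here, no two measured compounds differ in one place, so no measured step speaks to this change. The expectation rests mainly on compound 1 at 81.7 mL/min/kg as its anchor and stays correspondingly loose.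

In this assay the estimated move is a 1.6-fold lower number from compound 1 to compound 3 (0.21 log units; within the scatter) and it is expected to be small, towards slower clearance and not clearly beyond the scatter. For compound 3 the estimated value is 50 mL/min/kg with an expected range from 25 mL/min/kg to 90 mL/min/kg in this read-out.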

Compound 3, clearance: 16300 mL/min/kg
Compound 3: middle estimate off by 330-fold (2.51 log units), on the low side, outside the stated range (above it).
By their numbers in this assay, from the lowest: compounds 2 and 1 (each within the scatter of the next); then compound 3.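

In this assay the aromatic nitrogen of the core of compound 1 turns out to be a place where the substituent can move the read-out strongly: pyrrolidin-3-yl in place of ethyl gives a 200-fold higher number from compound 1 to compound 3 (2.30 log units; beyond the scatter) and so goes towards much faster clearance. Within the data shown here, this is the first step that differs in one place, and it brings in a ring, a nitrogen, a hydrogen-bond donor and a hydrogen-bond acceptor all at once, so it cannot assign the rise to any one of these. Among these compounds, nothing measured so far bears on why clearance moves this far.

Open, going by these compounds, is whether the ring or its nitrogen sets the step: cyclopentyl on the same aromatic nitrogen would carry a ring without the nitrogen, and 1-methylpyrrolidin-3-yl would keep the nitrogen without its hydrogen-bond donor. Also open, on these data alone, are how a longer chain such as propyl behaves at this place and whether a step of this size recurs when the amide side of compound 1 is changed.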